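Same Atoms, Rearranged: From One Fluorophenyl to Another

The compounds below may be only part of what the source reports. "The series", "measured", "known", "first", "only" and "open" are said of these compounds alone.

Compound 2 `O=C(CCCCCCc1nc2ccc(-c3cccc(F)c3)cc2[nH]1)NO` was tested in a functional assay on SK-OV-3 cells (Homo sapiens) for cytotoxicity (a higher number here means a weaker inhibitor, a lower number a stronger inhibitor), where compound 2 gives 1500 nM. Among the measured compounds shown here, that is the lowest of the two numbers known so far, yet its nearest neighbour, compound 1 `O=C(CCCCCCc1nc2ccc(F)cc2[nH]1)NO`, is close: in this assay compound 1 gives 1900 nM, and the step of a 1.3-fold lower number from compound 1 to compound 2 (0.10 log units; within the scatter) means the two cannot be told apart. Compound 3 `O=C(CCCCCCc1nc2ccc(-c3ccccc3F)cc2[nH]1)NO` is the next compound, and it differs from compound 2 by 2-fluorophenyl in place of 3-fluorophenyl on an aromatic carbon. For the measured compounds named here, the one measured step concerns a different change, the exchange of a lone fluorine for a whole 3-fluorophenyl group, and it stayed within the scatter; no measured step swaps one fluorophenyl for another. With so little to go on, the expected step is no change at the digits printed from compound 2 to compound 3 (within the scatter), that is, nothing beyond the scatter. Compound 3 is therefore estimated at 1500 nM, with a likely range from 700 nM to 3200 nM.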

Compound 3, half-maximal inhibitory concentration: 7400 nM
Estimate against measurement, compound 3: 4.9-fold (0.69 log units) below; measured number outside the range, above it.
By their numbers in this assay, from the lowest: compounds 2 and 1 (each within the scatter of the next); then compound 3.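

In this assay, among the compounds shown here, moving the fluorine within the added ring, with the atoms unchanged, gives the first step that clearly exceeds the scatter: a 4.9-fold higher number from compound 2 to compound 3 (0.69 log units; beyond the scatter). Compared with the lone fluoro group, 3-fluorophenyl gave no readable change, whereas 2-fluorophenyl gives a 3.9-fold higher number from compound 1 to compound 3 (0.59 log units; beyond the scatter), so at this aromatic carbon the result depends on which fluorophenyl is attached, not merely on the presence of one. No available evidence explains this difference between the two fluorophenyl groups.

Going by these compounds, it remains open how a plain phenyl group or a pyridine ring would compare at this same carbon, which would help show whether the fluorine itself matters. On these data alone, it is also open whether a chlorine or a methoxy group in place of that fluorine would give a similar number.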